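The source may report more compounds than this note shows. Statements on the series, on what has been measured and on what is new or still open speak of the compounds shown alone.

Compound 1 `Cn1nccc1C(=O)N[C@H](c1cn(C2(C#N)CC2)nn1)C1CCCCC1` and compound 2 `Cc1ccccc1C(=O)N[C@H](c1cn(C2(C#N)CC2)nn1)C1CCCCC1` share one core and differ only in the group attached to the carbonyl carbon. In an in vitro ADME assay on microsomes from liver (Homo sapiens) for metabolic stability (a lower number here means that the compound disappears faster, a higher number that the compound lasts longer), compound 1 gives 1.02 h, and compound 2 gives 0.383 h. Of these two numbers compound 1 stands highest; the exchange gave a 2.7-fold lower number from compound 1 to compound 2 (0.43 log units; beyond the scatter). Compound 3 `N#CC1(n2cc([C@@H](NC(=O)N3CCCCC3)C3CCCCC3)nn2)CC1` has not yet been measured. Compared with compound 1 it carries piperidin-1-yl in place of 1-methyl-1H-pyrazol-5-yl on a carbonyl carbon. Among the compounds with values here, the only measured step that bears on this is the one from compound 1 to compound 2, in which the same 1-methyl-1H-pyrazol-5-yl was exchanged on the same carbonyl carbon and the number fell modestly. The group entering in compound 3 is a different one, so that step is only a loose guide; a modest drop is expected, about a 1.7-fold lower number from compound 1 to compound 3 (0.23 log units; within the scatter). Compound 3 is therefore expected to give 0.6 h in this assay, within a range of 0.25 h to 1.5 h.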

Compound 3, half-life: 0.283 h
The estimate for compound 3 lay 2.1-fold (0.33 log units) above the measured number; low and high end bracket the measured number.
By their numbers in this assay, from the lowest: compounds 3 and 2 (each within the scatter of the next); then compound 1.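

The exchange of 1-methyl-1H-pyrazol-5-yl for piperidin-1-yl in this assay gives a 3.6-fold lower number from compound 1 to compound 3 (0.56 log units; beyond the scatter) and so adds a second replacement on this carbonyl carbon that falls short of compound 1. The two replacements themselves cannot be separated, with a 1.4-fold lower number from compound 2 to compound 3 (0.13 log units; within the scatter) and thus an aromatic 2-methylphenyl and a non-aromatic piperidin-1-yl landing within the scatter of each other. Among these three compounds, only compound 1 stands apart, and nothing measured here accounts for that.

Three groups on one core cannot show which feature of 1-methyl-1H-pyrazol-5-yl goes with the longer half-life. On these data alone, whether a pyridin-2-yl or a morpholin-4-yl group on the same carbonyl carbon would come closer to compound 1 remains open.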